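This account rests on a few compounds, and the source may have more. Where it says the series, first, only, none or still open, it means among the compounds named here.

Measured compounds:
- Compound 1 `Cc1ccc(NC(=S)NC(=O)c2cn(-c3ccccc3)nc2-c2ccc(F)cc2)cc1`: 2980 nM
- Compound 2 `Cc1ccc(-c2nn(-c3ccccc3)cc2C(=O)NC(=S)Nc2ccc(Cl)cc2)cc1`: 3650 nM
- Compound 3 `COc1ccc(NC(=S)NC(=O)c2cn(-c3ccccc3)nc2-c2ccc(OC)cc2)cc1`: 2570 nM

In a functional assay on NCI-H460 cells (Homo sapiens) for inhibition, read by CCK-8 assay, with a stated time of 48 h (on this read-out lower numbers stand for stronger inhibition and higher numbers for weaker inhibition), compound 1 gives 2980 nM. Among the three numbers shown, compound 1 stands second highest, but the other two lie close by: compound 3 gives 2570 nM and compound 2 gives 3650 nM, and both of these lie within the usual scatter of compound 1. On the numbers shown, then, the three compounds cannot be told apart in this assay.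

Compound 4 `Cc1ccc(NC(=S)NC(=O)c2cn(-c3ccccc3)nc2-c2ccccc2)cc1` has not yet been measured. It differs from compound 1 by hydrogen in place of fluoro on an aromatic carbon. Going by the values given here, no single-point step between measured compounds is available to calibrate this change, so any expectation rests on the structural difference alone, which is small. A step of no more than the scatter is expected in either direction, with no clear preference for a stronger or weaker number. Compound 4 is therefore expected to give about 3200 nM in this assay, within a range of 1400 nM to 7500 nM, and the step of a 1.1-fold higher number from compound 1 to compound 4 (0.03 log units; within the scatter) is estimated to stay within the scatter.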

Compound 4, half-maximal inhibitory concentration: 3960 nM
Beside the measured number, compound 4's estimate is 1.2-fold (0.09 log units) below it; measured number inside the range.
By their numbers in this assay, from the lowest: compounds 3, 1, 2 and 4 (each within the scatter of the next).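

In this assay, going by these compounds alone, the change from 4-fluorophenyl to phenyl gives a 1.3-fold higher number from compound 1 to compound 4 (0.12 log units; within the scatter), the first comparison here between compounds that differ in one place only. This step lies within the scatter, so on an aromatic carbon para to a large group, fluoro and hydrogen cannot be told apart on these numbers. Nothing measured here speaks to the reason for this result.

The compounds shown leave open whether an amine or a carboxylic acid at this same place would move the number beyond the scatter. They also leave open whether hydrogen in place of fluoro would read the same way on a core other than that of compound 1.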